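A Single Fluoro Added to a Very Strong Inhibitor

The source may hold more compounds than are shown below. What is called first, only, known or untested is meant among the compounds shown, and "the series" means these compounds.

For the measured compounds named here, compound 1 (`O=C(/C=C/c1cccnc1)NCCCCCc1ccc(S(=O)(=O)Nc2ccccc2)cc1`) gives 146 nM in a functional assay on K562 cells (Homo sapiens) for inhibition, read by CCK-8 assay, with a stated time of 72 h (a higher number here means a weaker inhibitor, a lower number a stronger inhibitor), and is the weakest of the three compounds measured so far. Compound 2 (`O=C(/C=C/c1cccnc1)NCCCCCc1cccc(S(=O)(=O)Nc2ccccc2)c1`) gives 16.3 nM in the same read-out. Compound 3 (`O=C(/C=C/c1cccnc1)NCCCCCCc1cccc(S(=O)(=O)Nc2ccccc2)c1`) gives 0.88 nM and holds the lowest number of the three, well beyond the usual scatter from both of the others.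

The next molecule, compound 4 (`O=C(/C=C/c1cccnc1)NCCCCCCc1cccc(S(=O)(=O)Nc2ccc(F)cc2)c1`), matches compound 3 except at one spot. Its phenylsulfamoyl group becomes a (4-fluorophenyl)sulfamoyl group (fluoro in place of hydrogen on an aromatic carbon), which puts fluoro in place of hydrogen on an aromatic carbon, para to a large group.

Going by the values given here, no two measured compounds differ in just one place, so these data offer no direct guide to this change. The swap adds only a single heavy atom, so only a small shift is expected, with no firm direction, starting from the value of compound 3 at 0.88 nM on this scale. The estimated step is a 1.3-fold higher number from compound 3 to compound 4 (0.10 log units; within the scatter) and is expected to stay within the usual scatter. Among the compounds with values here, compound 4 is therefore estimated at 1.1 nM with an expected range from 0.3 nM to 4 nM when tested in this assay for the first time.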

Compound 4, half-maximal inhibitory concentration: 0.93 nM
For compound 4 the middle estimate is 1.2-fold (0.07 log units) above the measured one, within the range that was stated.
By their numbers in this assay, from the lowest: compounds 3 and 4 (each within the scatter of the next); then compound 2; then compound 1.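

In this assay, putting fluoro in place of hydrogen on this aromatic carbon, para to a large group, gives a 1.1-fold higher number from compound 3 to compound 4 (0.02 log units; within the scatter). For the compounds shown here, this is the first comparison in the set between two compounds that differ in just one place, and it shows that the phenylsulfamoyl group can become a (4-fluorophenyl)sulfamoyl group with no readable change in the number, so the very low value of compound 3 survives the swap, with compound 4 at 0.93 nM in the same read-out. No supporting data are available to explain why this swap leaves the number within the scatter.

Fluoro adds only one heavy atom, so the compounds shown leave open whether this same spot would accept a larger or quite different group, such as methoxy, trifluoromethyl, an amine or a carboxylic acid. They also leave open whether the same fluoro would give so small a step on the shorter chain of compound 2, or on the differently substituted ring of compound 1, where the starting numbers are much higher.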